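Cyclohexyl in place of sec-butyl on the amine nitrogen

The compounds below may be only part of what the source reports. "The series", "measured", "known", "first", "only" and "open" are said of these compounds alone.

Measured compounds:
compound 1, `CCCNC(=C\C(=O)/C=C/c1ccc(O)c(OC)c1)/C=C/c1ccc(O)c(OC)c1`, 97%
compound 2, `CCC(C)NC(=C\C(=O)/C=C/c1ccc(OC(C)=O)c(OC)c1)/C=C/c1ccc(OC(C)=O)c(OC)c1`, 95%
compound 3, `C=CCNC(=C\C(=O)/C=C/c1ccc(O)c(OC)c1)/C=C/c1ccc(O)c(OC)c1`, 89%

In a functional assay on Caco-2 cells (Homo sapiens), read by fluorescence, tested at 1 uM (on this read-out lower numbers stand for a stronger effect and higher numbers for a weaker effect at the one concentration tested), compound 2 gives 95%, the second highest of the three numbers. Compound 1 gives 97%, and compound 3 gives 89%; both of these values lie within the scatter of that of compound 2, so no order among the three can be drawn from this assay.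

Compound 4, `COc1cc(/C=C/C(=O)/C=C(/C=C/c2ccc(OC(C)=O)c(OC)c2)NC2CCCCC2)ccc1OC(C)=O`, has not yet been measured. It differs from compound 2 in one place: cyclohexyl in place of sec-butyl on an amine nitrogen, which cut one bond further out reads (sec-butyl)amino to cyclohexylamino.

For the measured compounds named here, only one measured step alters the group on the amine nitrogen: a number 8 percentage points lower from compound 1 to compound 3 (within the scatter). That change is smaller than the present one, but it is the nearest guide, and it shows that a change at this position left this assay unmoved within the scatter. Compound 4 is therefore expected to show no step beyond the scatter, as a number 2 percentage points lower from compound 2 to compound 4 (within the scatter). Compound 4 is estimated at 93%, with a range from 80% to 100%.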

Compound 4, a percentage reported as activity, at one concentration (the size of the read-out at that concentration, not a potency): 89%
Estimate against measurement, compound 4: 4 percentage points above; the measured number falls inside the stated range.
By their numbers in this assay, from the lowest: compounds 3, 4, 2 and 1 (each within the scatter of the next).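

In this assay the exchange of sec-butyl for cyclohexyl on the amine nitrogen gives a number 6 percentage points lower from compound 2 to compound 4 (within the scatter) and thus extends what the earlier step showed for open chains: a six-membered carbon ring with more heavy atoms can stand at this position without a step beyond the scatter. For the compounds shown here, this also gives the first reading at this position on the core of compound 2, as the earlier step belonged to the core of compound 1. Nothing available explains the result or links it to any property of either group.

From the compounds shown here alone, whether a phenyl ring or a chain ending in a carboxylic acid on the amine nitrogen would give a step beyond the scatter remains open. So does whether cyclohexyl would give a similar step on the core of compound 1.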